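Swapping the acid-bearing acyl group for a sulfonyl group

A few compounds are considered here, and "the series" means these few. Any claim that something is new, unique, unknown or untested is made for them only; others in the source may bear on it.

In a functional assay on NCI-H441 cells (Homo sapiens) for antiproliferative activity, with a stated time of 24 h (on this read-out lower numbers stand for stronger inhibition and higher numbers for weaker inhibition), compound 1 (`O=C(O)/C=C/C(=O)N1C/C(=C\c2ccccc2F)C(=O)/C(=C/c2ccccc2F)C1`) gives 29000 nM, compound 2 (`O=C(O)COCC(=O)N1C/C(=C\c2ccccc2F)C(=O)/C(=C/c2ccccc2F)C1`) gives 310000 nM and compound 3 (`O=C1/C(=C/c2ccccc2F)CN(C(=O)C2CCCCC2C(=O)O)C/C1=C\c1ccccc1F`) gives 55000 nM. Compound 3 sits level with compound 1, at a 1.9-fold higher number from compound 1 to compound 3 (0.28 log units; within the scatter), and clearly under compound 2, at a 5.6-fold lower number from compound 2 to compound 3 (0.75 log units; beyond the scatter). Compound 4 (`Cc1ccc(S(=O)(=O)N2C/C(=C\c3ccccc3F)C(=O)/C(=C/c3ccccc3F)C2)cc1`) has (4-methylphenyl)sulfonyl in place of (2-carboxycyclohexyl)carbonyl on an amine nitrogen in a ring. The measured steps only exchange carboxy-bearing groups on a carbonyl carbon, the largest being an 11-fold higher number from compound 1 to compound 2 (1.03 log units; beyond the scatter), so they bear on this change only loosely. For the measured compounds named here, no sulfonyl compound has been measured yet. A modest move towards a lower number is expected, namely a 4.6-fold lower number from compound 3 to compound 4 (0.66 log units; beyond the scatter). The estimate for compound 4 is 12000 nM, with an expected range of 2500 nM to 50000 nM.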

Compound 4, half-maximal inhibitory concentration: 50000 nM
For compound 4 the middle estimate is 4.2-fold (0.62 log units) below the measured one; low and high end bracket the measured number.
By their numbers in this assay, from the lowest: compounds 1, 4 and 3 (each within the scatter of the next); then compound 2.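

At the amine nitrogen in a ring, (4-methylphenyl)sulfonyl, with no hydrogen-bond donor, holds the level of the acid-bearing acyl groups in this assay, with a 1.1-fold lower number from compound 3 to compound 4 (0.04 log units; within the scatter) and a 1.7-fold higher number from compound 1 to compound 4 (0.24 log units; within the scatter), both within the scatter. Compound 2 alone stands apart, with a 6.2-fold lower number from compound 2 to compound 4 (0.79 log units; beyond the scatter), so a carboxylic acid on this substituent is not needed to reach the level of compound 1 and compound 3. Nothing measured here explains this.

This change replaces the acyl link and the acid together, so their separate contributions remain unresolved. A sulfonyl group carrying a carboxylic acid or an amine would separate them.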